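Bromo in Place of Nitro on a Shared Core

This account rests on a few compounds, and the source may have more. Where it says the series, first, only, none or still open, it means among the compounds named here.

Measured so far in a functional assay on NB-4 cells (Homo sapiens) for cytotoxicity, read by CCK-8 assay, with a stated time of 24 h; a lower number here means a stronger inhibitor, a higher number a weaker inhibitor:
Compound 1, `C=CC(=O)N1C(=O)CC(c2ccc([N+](=O)[O-])cc2)Sc2ccccc21`: compound 1 gives 37700 nM.
Compound 2, `C=CC(=O)N1C(=O)CC(c2ccccc2Cl)Sc2ccccc21`: compound 2 gives 33800 nM.
Compound 3, `C=CC(=O)N1C(=O)CCSc2ccccc21`: compound 3 gives 22400 nM.

Compound 1 has the highest of the three numbers, yet its gaps to compound 2 and to compound 3 both lie within the scatter, so the three cannot be told apart. Compound 4, `C=CC(=O)N1C(=O)CC(c2ccc(Br)cc2)Sc2ccccc21`, differs from compound 1 in one place: bromo in place of nitro on an aromatic carbon. Going by the values given here, the only step measured, a 1.5-fold lower number from compound 2 to compound 3 (0.18 log units; within the scatter), concerns a different position and stayed within the scatter; no measured step exchanges one group for another on the aromatic ring. For compound 4 the expected step is therefore none beyond the scatter, a 1.1-fold lower number from compound 1 to compound 4 (0.03 log units; within the scatter). Compound 4 is estimated at 35000 nM, between 15000 nM and 80000 nM.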

Compound 4, half-maximal inhibitory concentration: 59400 nM
Compound 4: the middle estimate sits 1.7-fold (0.23 log units) below what was measured, within the range that was stated.
By their numbers in this assay, from the lowest: compounds 3, 2, 1 and 4 (each within the scatter of the next, the first and the last beyond it).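

Exchanging nitro for bromo on the aromatic ring gives a 1.6-fold higher number from compound 1 to compound 4 (0.20 log units; within the scatter) and so cannot be told from repeat-measurement noise, and the step of a 1.8-fold higher number from compound 2 to compound 4 (0.24 log units; within the scatter) likewise stays inside the scatter. Going by these compounds alone, the step of a 2.7-fold higher number from compound 3 to compound 4 (0.42 log units; beyond the scatter) is the first in this set to pass beyond the scatter, though only modestly, so placing 4-bromophenyl rather than hydrogen on the saturated ring carbon does separate two compounds. Nothing measured here explains that gap. From the compounds shown here alone, whether an amine or a carboxylic acid in place of bromo on the aromatic ring would move the number beyond the scatter remains open.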